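Phenyl in Place of Sec-Butyl: An Expected Non-Starter

The source may report more compounds than this note shows. Statements on the series, on what has been measured and on what is new or still open speak of the compounds shown alone.

Compound 1 `CCC(C)C1NC(=O)N(C2CCCC2)C1=O` was tested in a functional assay on CCRF-CEM cells (Homo sapiens) for inhibition; on this read-out higher numbers stand for weaker inhibition and lower numbers for stronger inhibition. For compound 1 the result is only a limit, > 200000 nM. Compound 3 `CC(C)C(NC(=O)NO)C(=O)NC1CCCC1` likewise gives only a limit in this assay, > 200000 nM. Compound 2 `CCC(C)C(NC(=O)n1nnc2ccccc21)C(=O)NC(c1ccccc1)c1ccccc1` gives an actual number in this assay, 139000 nM, which is still very weak inhibition. Compound 1 therefore sits at the limit of > 200000 nM in this assay, at which 2 of the 3 values shown sit, with nothing to set it apart from compound 3. Compound 4 `O=C1NC(c2ccccc2)C(=O)N1C1CCCC1` is the untested relative: phenyl in place of sec-butyl on a saturated ring carbon. For the measured compounds named here, no measured pair shows what this swap does. Because compound 1 sits at the limit of > 200000 nM in this assay, at which 2 of the 3 values shown sit, compound 4 is expected to stay near that limit. The step of a number no higher from compound 1 to compound 4 (the limit leaves the size open) is estimated as none beyond the scatter. Compound 4 is expected to give about 200000 nM, within 60000 nM to 500000 nM.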

Compound 4, half-maximal inhibitory concentration: > 200000 nM
Compound 4: only a limit was reported; the forecaster's own chance of this, stated with the estimate: 75%; the middle value lies on the limit itself.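

Compound 1 and compound 4 both give only limits in this assay, so no step between them can be read: the limit of > 200000 nM in this assay, at which 3 of the 4 values shown sit.

As far as these compounds go, whether phenyl in place of sec-butyl on a saturated ring carbon changes inhibition at all stays open.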